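This account rests on a few compounds, and the source may have more. Where it says the series, first, only, none or still open, it means among the compounds named here.

Measured compounds in an assay on isolated protein for inhibition of DNA topoisomerase 1 (Homo sapiens), with a stated time of 30 min, tested at 100 uM; on this read-out higher numbers stand for a stronger effect at the one concentration tested and lower numbers for a weaker effect:

- compound 1 `Oc1cccc(-c2cc(-c3ccncc3)nc(-c3cccc(Cl)c3)c2)c1` gives 0%
- compound 2 `Oc1cccc(-c2cc(-c3ccsc3)nc(-c3cccc(Cl)c3)c2)c1` gives 26.2%
- compound 3 `Oc1ccc(-c2cc(-c3ccncc3)nc(-c3cccc(Cl)c3)c2)cc1` gives 29.2%

Two single changes start from compound 1. The first is thiophen-3-yl in place of pyridin-4-yl on an aromatic carbon; it made a number 26.2 percentage points higher from compound 1 to compound 2 (beyond the scatter). The second is 4-hydroxyphenyl in place of 3-hydroxyphenyl on an aromatic carbon; it made a number 29.2 percentage points higher from compound 1 to compound 3 (beyond the scatter). Compound 3 has the highest number of the three, but compound 2 sits within the scatter of it, so no order between compound 2 and compound 3 is claimed.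

Compound 4 `Oc1ccc(-c2cc(-c3ccsc3)nc(-c3cccc(Cl)c3)c2)cc1` is not yet measured. It differs from compound 3 by thiophen-3-yl in place of pyridin-4-yl on an aromatic carbon. Within the data shown here, this is the same kind of change as the one from compound 1 to compound 2, on the same kind of place, next to the ring nitrogen and meta to a 3-chlorophenyl group; the surroundings differ only in that the place is meta to a 4-hydroxyphenyl group in compound 3 rather than meta to a 3-hydroxyphenyl group in compound 1. That difference between the two cores is 4-hydroxyphenyl in place of 3-hydroxyphenyl on an aromatic carbon.

Among the measured compounds shown here, with only one earlier instance of the change, the expectation rests on compound 1 and compound 2, where the step was a number 26.2 percentage points higher from compound 1 to compound 2 (beyond the scatter). From compound 3 a step of about a number 15.8 percentage points higher from compound 3 to compound 4 (beyond the scatter) is expected, somewhat smaller than the earlier one because compound 3 already starts from 29.2% and the two changes need not add in full. Compound 4 is therefore estimated at 45% in this assay, with a likely range from 22% to 68%.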

Compound 4, a percentage reported as inhibition, at one concentration (the size of the read-out at that concentration, not a potency): 26%
Compound 4: the middle estimate sits 19 percentage points above what was measured; low and high end bracket the measured number.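

In this assay, thiophen-3-yl in place of pyridin-4-yl does not carry from one core to the other, since on the core of compound 3 the same change gives a number 3.2 percentage points lower from compound 3 to compound 4 (within the scatter), and the two steps differ: the same change on two cores in this assay, a number 26.2 percentage points higher (beyond the scatter) from compound 1 to compound 2 and a number 3.2 percentage points lower (within the scatter) from compound 3 to compound 4, 29.4 percentage points apart, beyond the scatter of two such steps. The hydroxyl swap behaves the same way, with 4-hydroxyphenyl in place of 3-hydroxyphenyl giving a number 0.2 percentage points lower from compound 2 to compound 4 (within the scatter) on the thiophene-bearing core, and these two steps differ as well: the same change on two cores in this assay, a number 29.2 percentage points higher (beyond the scatter) from compound 1 to compound 3 and a number 0.2 percentage points lower (within the scatter) from compound 2 to compound 4, 29.4 percentage points apart, beyond the scatter of two such steps. Within these four compounds, either change lifts the number from compound 1, but making both gives no further rise, though this rests on a single pair of steps for each change, read at one concentration, so it shows neither a rule for other cores nor a difference in potency, and it gives no reason for the behaviour.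

The compounds shown leave open whether the same non-additive behaviour holds for other replacements of pyridin-4-yl, such as a furan-3-yl or a plain phenyl ring. They also leave open how the series reads with a methoxy group or a carboxylic acid in place of the hydroxyl group, or with another halogen such as fluorine in place of the chlorine of the 3-chlorophenyl group.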